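Notes on the step from compound 3 to compound 4

The compounds below may be only part of what the source reports. "The series", "measured", "known", "first", "only" and "open" are said of these compounds alone.

compound 1 `CCC1=C(O)c2c(oc(-c3ccc(SC)cc3)cc2=O)C(CC)(CC)C1=O`: 1.38 uM
compound 2 `CCC1=C(O)c2c(oc(-c3ccc(Br)cc3)cc2=O)C(CC)(CC)C1=O`: 15.7 uM
compound 3 `CCC1=C(O)c2c(oc(-c3cc(C)c(C)cc3C)cc2=O)C(CC)(CC)C1=O`: 4.37 uM
compound 4 `CCC1=C(O)c2c(oc(-c3ccc(OC)cc3C)cc2=O)C(CC)(CC)C1=O`: not yet measured

All values come from a functional assay on KBVIN cells (Homo sapiens) for antiproliferative activity, read by sulforhodamine B assay, with a stated time of 3 days; on this read-out higher numbers stand for an effect only at larger amounts of compound and lower numbers for an effect already at smaller amounts. Compound 3 holds the middle of the three numbers, and both of its neighbours lie beyond the scatter: a 3.2-fold higher number from compound 1 to compound 3 (0.50 log units; beyond the scatter) and a 3.6-fold lower number from compound 2 to compound 3 (0.56 log units; beyond the scatter). Both of these steps are modest.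

The next change is 4-methoxy-2-methylphenyl in place of 2,4,5-trimethylphenyl on an aromatic carbon. In words, it is 4-methoxy-2-methylphenyl in place of 2,4,5-trimethylphenyl on an aromatic carbon, next to the ring oxygen. Within the data shown here, no measured step makes this exact exchange, so the evidence is indirect. The three measured compounds differ only in this same aryl group, and the widest step among them is large: an 11-fold higher number from compound 1 to compound 2 (1.06 log units; beyond the scatter). Exchanges here can therefore move the number a long way, although three compounds set no rule.

The 4-methoxy of compound 4 reads closer to the 4-(methylsulfanyl) of compound 1 (1.38 uM) than to the 4-bromo of compound 2 (15.7 uM). That gives only a slight lean towards a lower number. The expected result in this assay is no step beyond the scatter, and the estimated step is a 1.5-fold lower number from compound 3 to compound 4 (0.16 log units; within the scatter).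

The estimate for compound 4 is 3 uM, with an expected range from 1 uM to 9 uM.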

Compound 4, concentration for half-maximal effect: 2.62 uM
Compound 4: the middle estimate sits 1.1-fold (0.06 log units) above what was measured; measured number inside the range.
By their numbers in this assay, from the lowest: compounds 1, 4 and 3 (each within the scatter of the next, the first and the last beyond it); then compound 2.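

In this assay, 4-methoxy-2-methylphenyl in place of 2,4,5-trimethylphenyl gives a 1.7-fold lower number from compound 3 to compound 4 (0.22 log units; within the scatter), so at this aromatic carbon a group with a hydrogen-bond acceptor and a carbon-only group with none are not told apart. The new compound also stays unseparated from the 4-(methylsulfanyl)phenyl compound, with a 1.9-fold higher number from compound 1 to compound 4 (0.28 log units; within the scatter), whereas 4-methoxy-2-methylphenyl in place of 4-bromophenyl gives a 6.0-fold lower number from compound 2 to compound 4 (0.78 log units; beyond the scatter), which leaves compound 2 beyond the scatter of each of the other three compounds. No measurement shown here offers an explanation for this grouping.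

Open, going by these compounds, is whether an aminophenyl or a carboxyphenyl group at this aromatic carbon would fall with compound 1, compound 3 and compound 4 or move towards compound 2. Also open, on these data alone, is what a propyl chain in place of the ethyl groups on the shared core would do, since all four compounds carry the same ethyl groups.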